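From Acetyl to Nitro on a Shared Core

The source may hold more compounds than are shown below. What is called first, only, known or untested is meant among the compounds shown, and "the series" means these compounds.

Measured in a functional assay on MCF7 cells (Homo sapiens) for antiproliferative activity, read by MTT assay, with a stated time of 72 h; a lower number here means a stronger inhibitor, a higher number a weaker inhibitor:
- compound 1 `Nc1nc(N)c2cc(CSC(=S)N3CCN(c4ccc(O)cc4)CC3)ccc2n1`: 5090 nM
- compound 2 `Nc1nc(N)c2cc(CSC(=S)N3CCN(c4ccc(Cl)c(Cl)c4)CC3)ccc2n1`: 2370 nM
- compound 3 `CC(=O)c1ccc(N2CCN(C(=S)SCc3ccc4nc(N)nc(N)c4c3)CC2)cc1`: 2490 nM

Compound 3 sits level with compound 2, as a 1.1-fold higher number from compound 2 to compound 3 (0.02 log units; within the scatter) shows. Compound 1 stands apart from it, and a 2.0-fold lower number from compound 1 to compound 3 (0.31 log units; beyond the scatter) gives the size of that gap.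

The next compound, compound 4 `Nc1nc(N)c2cc(CSC(=S)N3CCN(c4ccc([N+](=O)[O-])cc4)CC3)ccc2n1`, has not yet been measured. It carries nitro in place of acetyl on an aromatic carbon, para to a large group (nitro in place of acetyl on an aromatic carbon). Everything else stays the same.

Going by the values given here, no measured compound carries nitro, so the evidence is indirect. All three measured steps change only the aromatic group at this end of the molecule. Besides the two steps above, there is a 2.1-fold lower number from compound 1 to compound 2 (0.33 log units; beyond the scatter), which is also modest. Swapping this group has therefore moved the number only a little so far, and one of the three swaps left it within the scatter.

In this assay, the expected outcome is a 1.0-fold higher number from compound 3 to compound 4 (0.00 log units; within the scatter), with no change beyond the scatter in either direction. For compound 4 the estimated value is 2500 nM, with an expected range from 1200 nM to 5200 nM.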

Compound 4, half-maximal inhibitory concentration: 1470 nM
The estimate for compound 4 lay 1.7-fold (0.23 log units) above the measured number, and the stated range covers the measured number.
By their numbers in this assay, from the lowest: compounds 4, 2 and 3 (each within the scatter of the next); then compound 1.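

Nitro and acetyl have the same count of heavy atoms, and exchanging one for the other on this aromatic carbon leaves the result within the usual scatter of this assay (a 1.7-fold lower number from compound 3 to compound 4 (0.23 log units; within the scatter)). The nitro compound also sits level with the 3,4-dichlorophenyl compound (a 1.6-fold lower number from compound 2 to compound 4 (0.21 log units; within the scatter)), so three different aromatic groups now give results that cannot be told apart in this assay, and this end of the molecule accepts all of them about equally. Only the hydroxy compound stands apart from that group, and the new compound gives the widest gap seen so far, though it is still modest (a 3.5-fold lower number from compound 1 to compound 4 (0.54 log units; beyond the scatter)), which makes hydroxy the one group shown here that goes with a higher number.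

From the compounds shown here alone, whether an amine or a carboxylic acid on this same carbon would fall with compound 1 or with compounds 2, 3 and 4 remains open, as does whether a much larger aromatic group would still be accepted. Nothing available explains why the hydroxy compound differs from the other three.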